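Dichloroacetanilide series: bromo in place of methyl

This account rests on a few compounds, and the source may have more. Where it says the series, first, only, none or still open, it means among the compounds named here.

Working notes. Going by the values given here, the two measured members share the dichloroacetamide on an aniline. Compound 1 `O=C(Nc1cccc(I)c1)C(Cl)Cl` carries an iodo on the ring and in a functional assay on KB cells (Homo sapiens) for antiproliferative activity, read by MTT assay, with a stated time of 72 h (a lower number here means a stronger inhibitor, a higher number a weaker inhibitor), compound 1 gives 5250 nM. Compound 2 `O=C(Nc1cccc(S(=O)(=O)C(F)(F)F)c1)C(Cl)Cl` carries a trifluoromethylsulfonyl instead, and in this assay compound 2 gives 20600 nM. The two values differ by more than the usual scatter, with compound 1 the lower of the pair. Among the compounds with values here, no step between them is counted, so the comparison rests on the two numbers alone.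

Compound 3 `Cc1ccc(NC(=O)C(Cl)Cl)cc1` carries a methyl on the ring; in this assay the entry for compound 3 is "not determined" (no result reported), so compound 3 stands nowhere on the numbers shown and cannot anchor a step. Compound 4 `O=C(Nc1ccc(Br)cc1)C(Cl)Cl` differs from compound 3 by bromo in place of methyl on an aromatic carbon. No number exists for compound 3, so the size and direction of this step in this assay cannot be stated; the expectation for compound 4 has to lean on compound 1, the other ring-halogen member, which gives 5250 nM. On that basis compound 4 is expected to sit near 6500 nM in this assay, estimated within 2000 nM to 25000 nM, with the wide range reflecting the absence of any counted step.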

Compound 4, half-maximal inhibitory concentration: 21700 nM
Beside the measured number, compound 4's estimate is 3.3-fold (0.52 log units) below it, within the range that was stated.
By their numbers in this assay, from the lowest: compound 1; then compounds 2 and 4 (each within the scatter of the next).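

No new step can be read from compound 4, as compound 3, which carries methyl in place of bromo, has no single number in this assay. The compounds shown leave open whether bromo or methyl at that ring position gives the lower number. No measurement at hand bears on the value of compound 4.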